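Chloro for methoxy on the aryl group

A few compounds are considered here, and "the series" means these few. Any claim that something is new, unique, unknown or untested is made for them only; others in the source may bear on it.

Compound 1 `COc1ncc(-c2ccc3c(c2)N(c2ccc(C)cc2)C(=O)CO3)cc1NS(=O)(=O)c1ccc(F)cc1` gives 15400 nM
Compound 2 `COc1ccc(N2C(=O)COc3ccc(-c4cnc(Cl)c(NS(=O)(=O)c5ccc(F)cc5)c4)cc32)cc1` gives 36000 nM
Compound 3 `COc1ncc(-c2ccc3c(c2)N(C2CCCCC2)C(=O)CO3)cc1NS(=O)(=O)c1ccc(F)cc1` gives 30100 nM

All values come from a functional assay on MCF7 cells (Homo sapiens) for antiproliferative activity, read by MTT assay, with a stated time of 72 h (on this read-out higher numbers stand for weaker inhibition and lower numbers for stronger inhibition), and are read the same way. Compound 2 at 36000 nM lies within the scatter of compound 3 at 30100 nM. Compound 1 at 15400 nM gives a lower number than compound 2 by more than the scatter. Compound 4 `O=C1COc2ccc(-c3cnc(Cl)c(NS(=O)(=O)c4ccc(F)cc4)c3)cc2N1c1ccc(Cl)cc1` changes compound 2 by chloro in place of methoxy on an aromatic carbon and so reads chloro in place of methoxy on an aromatic carbon, 4-methoxyphenyl to 4-chlorophenyl. Among the measured compounds shown here, the only measured step is a 2.0-fold higher number from compound 1 to compound 3 (0.29 log units; within the scatter) with cyclohexyl in place of 4-methylphenyl on an amide-type nitrogen in a ring, and it stays within the scatter. For the measured compounds named here, no measured step shows this swap itself, so no step beyond the scatter is expected. An estimated 1.2-fold lower number from compound 2 to compound 4 (0.08 log units; within the scatter) is expected. For compound 4 the estimated value is 30000 nM with 12000 nM to 70000 nM as the expected range.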

Compound 4, half-maximal inhibitory concentration: 32800 nM
Estimate against measurement, compound 4: 1.1-fold (0.04 log units) below; the measured number falls inside the stated range.
By their numbers in this assay, from the lowest: compounds 1, 3, 4 and 2 (each within the scatter of the next, the first and the last beyond it).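

In this assay, chloro in place of methoxy on the aromatic carbon para to a large group gives a 1.1-fold lower number from compound 2 to compound 4 (0.04 log units; within the scatter), with both compounds at the high end of the series. The earlier step exchanged the whole group on the ring nitrogen, whereas this one shows that the para group of that aryl ring can change from methoxy to chloro with no shift beyond the scatter. No evidence bears on this result.

From the compounds shown here alone, whether an amine or a carboxylic acid at this position would shift the number remains open. So does whether the same swap reads alike on the core of compound 1.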